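Changing the amide substituent of a naphthalene-based phosphatase inhibitor

This account rests on a few compounds, and the source may have more. Where it says the series, first, only, none or still open, it means among the compounds named here.

Measured so far:
compound 1, `Cc1ccc(O)c(C(O)(C(F)(F)F)C(F)(F)F)c1`, 207000 nM;
compound 2, `Oc1c(-c2ccccc2)cccc1C(O)(C(F)(F)F)C(F)(F)F`, 157000 nM;
compound 3, `Cc1ccc(S(=O)(=O)NNC(=O)COc2ccc3cc(C(O)(C(F)(F)F)C(F)(F)F)c(O)cc3c2)cc1`, 16100 nM.

In an assay on isolated protein for inhibition of receptor-type tyrosine-protein phosphatase C (Homo sapiens), read by spectrophotometry (a lower number here means a stronger inhibitor, a higher number a weaker inhibitor), compound 3 gives the lowest number of the three, and its gaps to compound 2 and compound 1 both lie beyond the scatter, so it is the strongest inhibitor seen. Compound 4, `O=C(COc1ccc2cc(C(O)(C(F)(F)F)C(F)(F)F)c(O)cc2c1)NC1CC1`, has not been measured. It differs from compound 3 in one place: cyclopropyl in place of ((4-methylphenyl)sulfonyl)amino on an amide-type nitrogen. The large aromatic sulfonyl group, with its hydrogen-bond donor and acceptors, gives way to a small ring. Within the data shown here, no measured pair shows this change, so the expectation rests on compound 3 alone. A modest weakening, beyond the scatter, is expected, a 2.2-fold higher number from compound 3 to compound 4 (0.34 log units; beyond the scatter). Compound 4 is estimated at 35000 nM, within a range of 12000 nM to 110000 nM.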

Compound 4, half-maximal inhibitory concentration: > 20000 nM
Compound 4 was reported as a limit; the forecaster's own chance of this, stated with the estimate: 10%; the middle value does not contradict the limit.
By their numbers in this assay, from the lowest: compound 3; then compounds 2 and 1 (each within the scatter of the next).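

Compound 4 carries a limit rather than a number in this assay: > 20000 nM. Swapping ((4-methylphenyl)sulfonyl)amino for cyclopropyl on the amide-type nitrogen gives an at least 1.2-fold higher number from compound 3 to compound 4 (0.09 log units; that floor lies within the scatter), so the small ring brings no stronger inhibitor, though any real weakening remains unproven. The true size of this step cannot be told, because the reading stops at a limit: the limit of > 20000 nM in this assay, at which 1 of the 4 values shown sits.

Still open, from the compounds shown here alone, is whether a benzyl group, a longer alkyl chain or a carboxylic acid on this amide-type nitrogen would match compound 3.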